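This account rests on a few compounds, and the source may have more. Where it says the series, first, only, none or still open, it means among the compounds named here.

Four compounds share one core and differ only in two groups. Compound 1 `Cc1ccc(-c2nn(-c3ccccc3)cc2C(=O)NOCc2ccccc2F)cc1` serves as the reference; in a functional assay on HeLa cells (Homo sapiens) for antiproliferative activity, read by MTT assay, with a stated time of 48 h, in the presence of a further agent that is not named here (a lower number here means a stronger inhibitor of growth, a higher number a weaker inhibitor of growth), compound 1 gives 1180 nM. Compound 2 `Cc1ccc(-c2nn(-c3ccccc3)cc2C(=O)NOCc2ccccc2Cl)cc1` carries chloro in place of fluoro on an aromatic carbon, and in this assay compound 2 gives 4680 nM, so that a 4.0-fold higher number from compound 1 to compound 2 (0.60 log units; beyond the scatter). Compound 3 `COc1ccc(-c2nn(-c3ccccc3)cc2C(=O)NOCc2ccccc2F)cc1` differs from compound 1 in its core: methoxy in place of methyl on an aromatic carbon. In this assay compound 3 gives 2900 nM, and a 2.5-fold higher number from compound 1 to compound 3 (0.39 log units; beyond the scatter). Compound 4 `COc1ccc(-c2nn(-c3ccccc3)cc2C(=O)NOCc2ccccc2Cl)cc1`, not yet measured, stands to compound 3 exactly as compound 2 stands to compound 1: chloro in place of fluoro on an aromatic carbon. The place of the change reads the same word for word in both pairs, so it is the same change, made twice among these compounds. Its only measured occurrence is a 4.0-fold higher number from compound 1 to compound 2 (0.60 log units; beyond the scatter), and the expectation for compound 4 rests on that alone, assuming the change behaves on the core of compound 3 as it did on the core of compound 1. For compound 4 the step expected in this assay is therefore a 3.6-fold higher number from compound 3 to compound 4 (0.56 log units; beyond the scatter). In this assay compound 4 is thus estimated at 10500 nM, with a likely range from 4000 nM to 28000 nM.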

Compound 4, concentration for 50% growth inhibition: 3480 nM
The estimate for compound 4 lay 3.0-fold (0.48 log units) above the measured number, and the stated range ends above it.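

Carried onto a second core, chloro in place of fluoro did not keep its size: the same change on two cores in this assay, a 4.0-fold higher number (0.60 log units; beyond the scatter) from compound 1 to compound 2 and a 1.2-fold higher number (0.08 log units; within the scatter) from compound 3 to compound 4, 3.3-fold (0.52 log units) apart, beyond the scatter of two such steps

Methoxy in place of methyl did not keep its size either: the same change on two cores in this assay, a 2.5-fold higher number (0.39 log units; beyond the scatter) from compound 1 to compound 3 and a 1.3-fold lower number (0.13 log units; within the scatter) from compound 2 to compound 4, 3.3-fold (0.52 log units) apart, beyond the scatter of two such steps

The new steps, a 1.2-fold higher number from compound 3 to compound 4 (0.08 log units; within the scatter) and a 1.3-fold lower number from compound 2 to compound 4 (0.13 log units; within the scatter), close a single square of four compounds, so the two gaps are one observation seen from two sides: they show that in this set the two changes do not simply add up, but they do not show why, or which size either change would take on any further core.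

The compounds shown leave open whether compound 1, with its methyl and fluoro groups together, is a lone exception or whether other pairings would behave the same way. They also leave open what bromo in place of chloro, or ethoxy in place of methoxy, would do on these cores.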